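The source may report more compounds than this note shows. Statements on the series, on what has been measured and on what is new or still open speak of the compounds shown alone.

Three compounds have been measured so far:
compound 1, `Cc1cccc(/C(N)=N/NC(=S)N2CCCCC2)n1`, gives 27.1%;
compound 2, `N/C(=N\NC(=S)N1CCOCC1)c1ccccn1`, gives 44.5%;
compound 3, `Cc1ccnc(/C(N)=N/NC(=S)N2CCCCC2)c1`, gives 29.4%.

All three were tested in a functional assay on MCF7 cells (Homo sapiens) for cytotoxicity, read by MTT assay, with a stated time of 72 h, tested at 3 uM; a lower number here means less inhibition of growth, a higher number more inhibition of growth at the concentration tested. Compound 3 stands second highest of the three numbers. Its nearest neighbour is compound 1, whose number is lower by a margin within the usual scatter, so the two cannot be told apart on this evidence. Compound 2 is furthest away; its number lies above that of compound 3 by a margin beyond the scatter.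

Compound 4, `N/C(=N\NC(=S)N1CCCCC1)c1ccccn1`, has not yet been measured. It differs from compound 3 in one place: hydrogen in place of methyl on an aromatic carbon. Within the data shown here, no pair of measured compounds differs in this one place alone, so no measured step shows what the change does on its own. Compound 2 carries hydrogen at that place and gives the highest of the three numbers, but it also differs from compound 4 elsewhere, so its value is only a loose hint. A small rise in this assay is expected, most likely within the scatter. Compound 4 is expected to give 35%, with a plausible range from 20% to 50%. This corresponds to an expected step of a number 5.6 percentage points higher from compound 3 to compound 4 (within the scatter).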

Compound 4, percent growth inhibition at one concentration: 38.6%
Compound 4: middle estimate off by 3.6 percentage points, on the low side, and the stated range covers the measured number.
By their numbers in this assay, from the lowest: compounds 1, 3, 4 and 2 (each within the scatter of the next, the first and the last beyond it).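

In this assay, hydrogen in place of methyl on the aromatic carbon opposite the ring nitrogen gives a number 9.2 percentage points higher from compound 3 to compound 4 (within the scatter), the first measured view of this change on its own, and the step is too small to separate from ordinary repeat variation. With the methyl on a different aromatic carbon, the same exchange gives a number 11.5 percentage points higher from compound 1 to compound 4 (beyond the scatter), a modest step that does clear the scatter, although compound 1 at 27.1% and compound 3 at 29.4% cannot themselves be told apart, so these numbers do not show that the two methyl places differ. The new compound also links the two ring types: piperidin-1-yl in place of morpholin-4-yl on a thiocarbonyl carbon gives a number 5.9 percentage points lower from compound 2 to compound 4 (within the scatter), which lies within the scatter, so this exchange shows no clear effect in this assay.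

Nothing available here explains any of these numbers. From the compounds shown here alone, whether a different group at the aromatic carbon opposite the ring nitrogen, such as a methoxy group, a chlorine atom or an amine, would shift the number beyond the scatter remains open.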